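The source may hold more compounds than are shown below. What is called first, only, known or untested is meant among the compounds shown, and "the series" means these compounds.

Measured in a toxicity assay on CHO cells (Cricetulus griseus) for cytotoxicity, read by MTT assay, with a stated time of 72 h; on this read-out lower numbers stand for stronger inhibition and higher numbers for weaker inhibition (cytotoxicity series):
- compound 1 (`O=C1CS/C(=N\c2ccccc2)N1Cc1ccco1`): "not determined" (no result reported)
- compound 2 (`O=C1/C(=C/c2ccc([N+](=O)[O-])cc2)S/C(=N\c2ccccc2)N1Cc1ccco1`): "not determined" (no result reported)
- compound 3 (`O=C1/C(=C/c2ccc(O)cc2)S/C(=N\c2ccccc2)N1Cc1ccco1`): > 250000 nM

Compound 3 is the only one of the three with a result, and its > 250000 nM is a limit and not a number. That places it at the limit of > 250000 nM in this assay, at which 1 of the 3 values shown sits. Among the measured compounds shown here, no measured step is available.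

Compound 4 (`Cc1ccc(/C=C2\S/C(=N\c3ccccc3)N(Cc3ccco3)C2=O)cc1`) is compound 3 with methyl in place of hydroxy on an aromatic carbon, the change from 4-hydroxyphenyl to 4-methylphenyl. In this assay no step beyond the scatter is expected, and the estimated step is an at least 1.2-fold lower number from compound 3 to compound 4 (0.09 log units; that floor lies within the scatter). A further limit reading is also likely. For compound 4 the estimated value is 200000 nM, with an expected range from 60000 nM to 400000 nM.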

Compound 4, half-maximal inhibitory concentration: 185000 nM
Estimate against measurement, compound 4: 1.1-fold (0.03 log units) above; the range from low to high includes it.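

In this assay, among the compounds shown here, compound 4 gives the first reading of the series that is a number and not a limit, so 4-methylphenyl in place of 4-hydroxyphenyl gives a readable value at this position. On these data alone, the step reads as an at least 1.3-fold lower number from compound 3 to compound 4 (0.13 log units; that floor lies within the scatter) and is only a floor, so its full size stays unknown. Compound 3 stands as a limit and not a number: the limit of > 250000 nM in this assay, at which 1 of the 4 values shown sits.

Open, as far as these compounds go, is how an amine or a carboxylic acid on this aromatic carbon would read in this assay and whether any group there gives a much lower number than compound 4 does.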